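Swapping methyl for trifluoromethoxy: compound 2 to compound 4

A few compounds are considered here, and "the series" means these few. Any claim that something is new, unique, unknown or untested is made for them only; others in the source may bear on it.

Values measured in a functional assay on T47D cells (Homo sapiens) for cytotoxicity, read by MTT assay, with a stated time of 2 days (on this read-out lower numbers stand for stronger inhibition and higher numbers for weaker inhibition), are these:
- Compound 1 `Cc1ccc2nc(-c3ccccc3N(C)C)[nH]c(=O)c2c1` gives 26700 nM as a number
- Compound 2 `Cc1cccc(-c2nc3ccc(C)cc3c(=O)[nH]2)c1` gives > 50000 nM as a limit
- Compound 3 `Cc1ccc2c(=O)[nH]c(-c3cccc4ccccc34)nc2c1` gives > 50000 nM as a limit

Compound 2 gives only a limit and no number, sitting at the limit of > 50000 nM in this assay, at which 2 of the 3 values shown sit, and so offering no exact starting point. Compound 4 `Cc1ccc2nc(-c3cccc(OC(F)(F)F)c3)[nH]c(=O)c2c1` keeps the shared core and carries trifluoromethoxy in place of methyl on an aromatic carbon, meta to a large group. For the measured compounds named here, no measured pair shows what this swap does. A step of an at least 1.2-fold lower number from compound 2 to compound 4 (0.09 log units; that floor lies within the scatter) is expected in this assay to stay within the usual scatter, with no firm direction. For compound 4 the estimated value is 40000 nM within an expected range from 12000 nM to 70000 nM and a limit instead of a number remains possible.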

Compound 4, half-maximal inhibitory concentration: > 50000 nM
Compound 4 ended at the assay's limit; the forecaster's own chance of this, stated with the estimate: 55%; middle value at least 1.2-fold (0.09 log units) away from the limit.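

Compound 2 and compound 4 both give a limit and not a number, so the step from methyl to trifluoromethoxy between them cannot be read. The compounds shown leave open whether this swap changes activity at all.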